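Pyridin-4-yl in Place of 4-Chlorophenyl in an Inactive Series

The source may report more compounds than this note shows. Statements on the series, on what has been measured and on what is new or still open speak of the compounds shown alone.

Compound 1, `COc1cc(-c2noc(-c3ccncc3)n2)ccc1OCc1ccccc1`: > 1000000 nM
Compound 2, `COc1ccc(-c2noc(-c3ccc(Cl)cc3)n2)cc1OC1CCCC1`: > 1000000 nM
Compound 3, `Fc1ccc(-c2nc(-c3ccccc3)no2)cc1`: > 1000000 nM

All three were tested in a functional assay on HCT-116 cells (Homo sapiens) for antiproliferative activity, read by MTT assay, with a stated time of 24 h; a lower number here means a stronger inhibitor, a higher number a weaker inhibitor. None of the three values is a measured number. Each is a limit of the assay, as the limit of > 1000000 nM in this assay, at which 3 of the 3 values shown sit, shows. Compound 2 therefore stands at that limit, and nothing separates it from compound 1 or compound 3 on the numbers shown. For the measured compounds named here, no step between measured compounds can be drawn from such data, so no trend exists to build on.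

Compound 4, `COc1ccc(-c2noc(-c3ccncc3)n2)cc1OC1CCCC1`, is compound 2 with pyridin-4-yl in place of 4-chlorophenyl on an aromatic carbon. Compound 1 already carries pyridin-4-yl on the same kind of ring carbon and sits at the limit, which gives no hint that this group brings activity. The step expected in this assay from compound 2 to compound 4 is none beyond the scatter, with a high chance that the result is again only a limit. Compound 4 is therefore estimated at 1500000 nM, in a range from 300000 nM to 10000000 nM. The expected step is a step that the limit leaves unreadable from compound 2 to compound 4.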

Compound 4, half-maximal inhibitory concentration: > 1000000 nM
Compound 4 gave a limit, no number; the forecaster's own chance of this, stated with the estimate: 85%; the middle value is on the limit's open side.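

Compound 4 gives > 1000000 nM, which is a limit and not a number. No step from compound 2 to compound 4 can be read, because both values are limits: the limit of > 1000000 nM in this assay, at which 4 of the 4 values shown sit.

The compounds shown leave open whether swapping 4-chlorophenyl for pyridin-4-yl changes anything in this assay, and what structure would give a readable number there.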